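From phenyl to 4-hydroxyphenyl: a step on a limit

The compounds below may be only part of what the source reports. "The series", "measured", "known", "first", "only" and "open" are said of these compounds alone.

Compound 1 (`O=[N+]([O-])c1c(CS(=O)(=O)c2ccccc2)nc2c(-c3ccccc3)cc(Cl)cn12`) was examined in an ADME assay on HepG2 cells (Homo sapiens) for cytotoxicity, read by MTT assay, with a stated time of 72 h; a lower number here means that less compound is tolerated, a higher number that more compound is tolerated. In this assay compound 1 gives > 15600 nM, which is a limit and not a number. Among the measured compounds shown here, its only measured neighbour is compound 2 (`COc1ccc(-c2cc(Cl)cn3c([N+](=O)[O-])c(CS(=O)(=O)c4ccccc4)nc23)cc1`), which carries methoxy in place of hydrogen on an aromatic carbon. In this assay compound 2 gives > 3900 nM, and this too is a limit.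

Compound 3 (`O=[N+]([O-])c1c(CS(=O)(=O)c2ccccc2)nc2c(-c3ccc(O)cc3)cc(Cl)cn12`) has not yet been measured. It differs from compound 1 by hydroxy in place of hydrogen on an aromatic carbon, a change from phenyl to 4-hydroxyphenyl. For the measured compounds named here, the one measured step that bears on this change is a step that the two limits leave unreadable from compound 1 to compound 2, also a substitution on an aromatic carbon. Its size cannot be read, so it offers no magnitude or direction to carry over. The expectation therefore rests on the standing of compound 1, and no step beyond the scatter is expected in this assay. The expected value for compound 3 is 20000 nM, with an estimated range of 6000 nM to 60000 nM. This estimate means an expected step that the limit leaves unreadable from compound 1 to compound 3.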

Compound 3, half-maximal cytotoxic concentration: > 12500 nM
Compound 3 was reported as a limit; the forecaster's own chance of this, stated with the estimate: 60%; the middle value lies beyond the limit too.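

In this assay compound 3 gives > 12500 nM, which is a limit. Among the compounds shown here, compound 1 and compound 2 also stand only at limits, so no step among compound 1, compound 2 and compound 3 can be read. The compounds shown leave open the size and direction of any effect of hydroxy or methoxy on cytotoxicity.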